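This account rests on a few compounds, and the source may have more. Where it says the series, first, only, none or still open, it means among the compounds named here.

Measured compounds:
compound 1, `CN(C(=O)CCc1ccccc1)c1ccc2[nH]c(-c3n[nH]c4ccccc34)cc2n1`, 4730 nM in a functional assay on HL-60 cells (Homo sapiens) for antiproliferative activity, read by MTT assay, with a stated time of 72 h; a lower number here means a stronger inhibitor, a higher number a weaker inhibitor
compound 2, `COc1ccc(C(=O)N(C)c2ccc3[nH]c(-c4n[nH]c5ccccc45)cc3n2)cc1`, 3320 nM
compound 3, `CN(C(=O)c1ccc([N+](=O)[O-])cc1)c1ccc2[nH]c(-c3n[nH]c4ccccc34)cc2n1`, 6800 nM

Compound 2 has the lowest number of the three in this assay. Its gap to compound 1 is small, since a 1.4-fold lower number from compound 1 to compound 2 (0.15 log units; within the scatter), whereas the step of a 2.0-fold higher number from compound 2 to compound 3 (0.31 log units; beyond the scatter) is a modest one beyond the scatter. The unmeasured compound 4, `CN(c1ccc2[nH]c(-c3n[nH]c4ccccc34)cc2n1)S(=O)(=O)c1ccc(Br)cc1`, differs from compound 2 by a single change: (4-bromophenyl)sulfonyl in place of (4-methoxyphenyl)carbonyl on a nitrogen on an aromatic ring.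

Among the measured compounds shown here, no measured step swaps a carbonyl for a sulfonyl. For the measured compounds named here, the steps that bear on it are the acyl variations around the shared core: a 1.4-fold lower number from compound 1 to compound 2 (0.15 log units; within the scatter) and a 1.4-fold higher number from compound 1 to compound 3 (0.16 log units; within the scatter) both stayed within the scatter, and only a 2.0-fold higher number from compound 2 to compound 3 (0.31 log units; beyond the scatter), exchanging the group on the aromatic ring, moved beyond it. Compound 4 is therefore expected to sit near compound 2 or somewhat higher, with an estimated step of a 1.5-fold higher number from compound 2 to compound 4 (0.18 log units; within the scatter). For compound 4 the expected value is 5000 nM, with a range from 2000 nM to 12000 nM.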

Compound 4, half-maximal inhibitory concentration: 6240 nM
Estimate against measurement, compound 4: 1.2-fold (0.10 log units) below, and the stated range covers the measured number.
By their numbers in this assay, from the lowest: compounds 2, 1, 4 and 3 (each within the scatter of the next, the first and the last beyond it).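

In this assay the series now holds a sulfonyl on this nitrogen, and the (4-bromophenyl)sulfonyl group gives a 1.9-fold higher number from compound 2 to compound 4 (0.27 log units; within the scatter) and a 1.3-fold higher number from compound 1 to compound 4 (0.12 log units; within the scatter) as its two readings against the carbonyl-linked groups. The nitrogen thus carries a sulfonyl as well as a carbonyl without a step beyond the scatter, although the step from the (4-methoxyphenyl)carbonyl group exchanges the linking group and the ring substituent together, so the two changes cannot be told apart. No available evidence explains this result.

As far as these compounds go, a (4-methoxyphenyl)sulfonyl group would separate those two changes, and how it would read remains open. Also open, from the compounds shown here alone, is whether an amine or a carboxylic acid on that phenyl ring, or a longer chain in place of the methyl on this nitrogen, would move the number beyond the scatter.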